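The source may report more compounds than this note shows. Statements on the series, on what has been measured and on what is new or still open speak of the compounds shown alone.

Measured so far: compound 1 `OC[C@H]1OC(n2cnc3c(Nc4ccccc4)nccc32)[C@H](O)[C@@H]1O` with 4%; compound 2 `CN(C)c1[nH]ccc2ncnc1-2` with 8%.

Both were tested in a functional assay (Homo sapiens) for inhibition of Nucleic Acid, tested at 100 uM; on this read-out lower numbers stand for less inhibition and higher numbers for more inhibition at the one concentration tested (going by the name of the read-out). Compound 1 gives 4% and compound 2 gives 8%; the two numbers lie within the usual scatter of each other, so neither shows clear inhibition. Compound 3 `OCCNc1nccc2c1ncn2C1O[C@H](CO)[C@@H](O)[C@H]1O` differs from compound 1 in one place: 2-hydroxyethyl in place of phenyl on a nitrogen on an aromatic ring. Within the data shown here, no pair of measured compounds shows what such a change does here. With compound 1 at 4%, the expected step is a number 1 percentage points higher from compound 1 to compound 3 (within the scatter), none beyond the scatter. Compound 3 is therefore estimated at 5%, within -10% to 20%.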

Compound 3, a percentage reported as inhibition, at one concentration (the size of the read-out at that concentration, not a potency): 0%
For compound 3 the middle estimate is 5 percentage points above the measured one, within the range that was stated.
By their numbers in this assay, from the lowest: compounds 3, 1 and 2 (each within the scatter of the next).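

In this assay, putting 2-hydroxyethyl in place of phenyl on a nitrogen on an aromatic ring gives a number 4 percentage points lower from compound 1 to compound 3 (within the scatter). At this position, then, the six-membered aromatic ring and the short chain without a ring read alike, and neither brings clear inhibition at the one concentration tested. No other data bear on this result. Still open, on these data alone, is whether any group on this nitrogen can lift the read-out beyond the scatter. A longer chain ending in an amine or in a carboxylic acid would test this.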